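A few compounds are considered here, and "the series" means these few. Any claim that something is new, unique, unknown or untested is made for them only; others in the source may bear on it.

Working notes on the series in a functional assay on HCT-116 cells (Homo sapiens) for antiproliferative activity, read by MTT assay, with a stated time of 72 h; a lower number here means a stronger inhibitor, a higher number a weaker inhibitor.

Compound 1 `Cc1ccc(S(=O)(=O)NCc2cn(C[C@H](O)[C@H]3OC(=O)C(OCc4ccccc4)=C3OCc3ccccc3)nn2)cc1` carries a ((4-methylphenyl)sulfonyl)amino group on the triazole methylene; in this assay compound 1 gives 13100 nM, the lowest of the two numbers in hand. Compound 3 `O=C1O/C(=C\Cn2cc(-c3cccc(O)c3)nn2)C(OCc2ccccc2)=C1OCc1ccccc1`, which bears a 3-hydroxyphenyl directly on the triazole, gives 63600 nM in this assay, a higher number than compound 1 and beyond the scatter. Compound 2 `Cc1ccc(-c2cn(C/C=C3\OC(=O)C(OCc4ccccc4)=C3OCc3ccccc3)nn2)cc1` returns only a limit in this assay, > 100000 nM, and no number. Within the data shown here, the single measured step, an at least 1.5-fold lower number from compound 2 to compound 3 (0.19 log units; that floor lies within the scatter), is 3-hydroxyphenyl in place of 4-methylphenyl on an aromatic carbon; its floor lies within the scatter, and it rests on a limit, (the limit of > 100000 nM in this assay, at which 1 of the 3 values shown sits), so it sets no firm size.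

Compound 4 `O=C1O[C@H]([C@@H](O)Cn2cc(CNS(=O)(=O)c3ccc(Cl)cc3)nn2)C(OCc2ccccc2)=C1OCc1ccccc1` differs from compound 1 by chloro in place of methyl on an aromatic carbon, para to a large group, within the ((4-methylphenyl)sulfonyl)amino arm. No measured step touches this sulfonyl arm, and the only aryl change shown, an at least 1.5-fold lower number from compound 2 to compound 3 (0.19 log units; that floor lies within the scatter), was small. The expectation is therefore no step beyond the scatter in this assay, a 1.1-fold lower number from compound 1 to compound 4 (0.04 log units; within the scatter). Compound 4 is estimated at 12000 nM, with a range of 5000 nM to 32000 nM.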

Compound 4, half-maximal inhibitory concentration: 8380 nM
Compound 4: the middle estimate sits 1.4-fold (0.16 log units) above what was measured; low and high end bracket the measured number.
By their numbers in this assay, from the lowest: compounds 4 and 1 (each within the scatter of the next); then compound 3. At a limit, above all of these: compound 2.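

The sulfonyl arm now has its first measured step in this assay: chloro in place of methyl on an aromatic carbon, para to a large group, gives a 1.6-fold lower number from compound 1 to compound 4 (0.19 log units; within the scatter). Unlike the earlier aryl step, which rested on a limit, this one has a number at both ends, so its size can be read, and 4-methylphenyl and 4-chlorophenyl cannot be told apart at this position. Nothing in hand gives a measured property that bears on this step, so it stands as a size without a cause.

Still open, as far as these compounds go, is what a clearly different group in place of the chloro, such as an amine or a carboxylic acid, would give in this assay, since a single exchange of methyl for chloro says nothing about how far this position can be changed before the number moves beyond the scatter. Compound 1 and compound 4 differ from compound 3 in more than one place, so the compounds shown do not separate the contribution of the ((4-chlorophenyl)sulfonyl)amino arm from the other differences.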